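This account rests on a few compounds, and the source may have more. Where it says the series, first, only, none or still open, it means among the compounds named here.

Measured in a functional assay on A549 cells (Homo sapiens) for cytotoxicity, read by sulforhodamine B assay, with a stated time of 3 days; a higher number here means that more compound is needed for the effect, a lower number that less compound is needed:
- compound 1 `COC(=O)c1c(C)coc1-c1ccc2c(c1OC)CCCC2(C)C`: 61 uM
- compound 2 `CCOc1c(-c2occ(C)c2CO)ccc2c1CCCC2(C)C`: 22.9 uM
- compound 3 `COCc1c(C)coc1-c1ccc2c(c1OC)CCCC2(C)C`: 19.4 uM

Compound 3 sits clearly under compound 1, but its number is within the usual scatter of the number for compound 2. The next structure, compound 4 `COc1c(-c2occ(C)c2CO)ccc2c1CCCC2(C)C`, changes the methoxymethyl group of compound 3 to hydroxymethyl: hydrogen in place of methyl on an oxygen on a saturated carbon.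

Within the data shown here, only one measured step touches this group. It is a 3.1-fold lower number from compound 1 to compound 3 (0.50 log units; beyond the scatter), a modest change that made methoxymethyl from methoxycarbonyl, so it shows that this part of the molecule can shift the number, but it does not test the new change directly. Closer evidence comes from compound 2, which also carries hydroxymethyl and gives 22.9 uM, close to compound 3 at 19.4 uM.

No shift beyond the scatter is therefore expected in this assay, and no direction can be favoured. The expected result is a 1.1-fold higher number from compound 3 to compound 4 (0.05 log units; within the scatter). For compound 4 the estimated value is 22 uM, with an expected range from 11 uM to 45 uM.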

Compound 4, concentration for half-maximal effect: 23.3 uM
Estimate against measurement, compound 4: 1.1-fold (0.02 log units) below; low and high end bracket the measured number.
By their numbers in this assay, from the lowest: compounds 3, 2 and 4 (each within the scatter of the next); then compound 1.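

In this assay, taking the methyl off the oxygen of methoxymethyl gives a 1.2-fold higher number from compound 3 to compound 4 (0.08 log units; within the scatter), so hydroxymethyl and methoxymethyl cannot be told apart at this position. Replacing methoxycarbonyl with hydroxymethyl gives a 2.6-fold lower number from compound 1 to compound 4 (0.42 log units; beyond the scatter), so among the three groups seen here, only methoxycarbonyl stands apart. The other oxygen substituent also tolerates a change: hydrogen in place of methyl on a saturated chain carbon bound to an oxygen on an aromatic ring gives a 1.0-fold higher number from compound 2 to compound 4 (0.01 log units; within the scatter), which lies within the scatter too.

No evidence is available to explain these results. Still open, on these data alone, is whether a carboxylic acid or an amine on this aromatic carbon would move the number any further than these groups do.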